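This account rests on a few compounds, and the source may have more. Where it says the series, first, only, none or still open, it means among the compounds named here.

Working notes on the series. Within the data shown here, in an assay on U2OS cells for inhibition of secreted frizzled-related protein 1 (Homo sapiens), read by a luciferase reporter, with a stated time of 18 h (a higher number here means that more compound is needed for the effect, a lower number that less compound is needed), compound 1 `O=C(c1ccccc1)N1CCC(NS(=O)(=O)c2cc(S(=O)(=O)c3ccccc3)ccc2C(F)(F)F)CC1` gives 250 nM, and compound 2 `O=C(c1ccc(Cl)cc1)N1CCC(NS(=O)(=O)c2cc(S(=O)(=O)c3ccccc3)ccc2C(F)(F)F)CC1` gives 1800 nM, the highest of the two numbers; the only step so far is a 7.2-fold higher number from compound 1 to compound 2 (0.86 log units; beyond the scatter), chloro in place of hydrogen on an aromatic carbon. Compound 3 `O=C(O)c1ccc(S(=O)(=O)N2CCC(NS(=O)(=O)c3cc(S(=O)(=O)c4ccccc4)ccc3C(F)(F)F)CC2)cc1` is not yet measured. Its difference from compound 2: (4-carboxyphenyl)sulfonyl in place of (4-chlorophenyl)carbonyl on an amine nitrogen in a ring. Among the measured compounds shown here, no measured step touches this kind of change, so the one step recorded gives no direct guide. Compound 3 is therefore expected near compound 1's level, with wide uncertainty, the expected step being a 2.3-fold lower number from compound 2 to compound 3 (0.35 log units; beyond the scatter). Compound 3 is estimated at 800 nM, within 150 nM to 5000 nM.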

Compound 3, half-maximal effective concentration: 110 nM
For compound 3 the middle estimate is 7.3-fold (0.86 log units) above the measured one, outside the stated range (below it).
By their numbers in this assay, from the lowest: compound 3; then compound 1; then compound 2.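

In this assay, (4-carboxyphenyl)sulfonyl on the amine nitrogen in a ring brings a 16-fold lower number from compound 2 to compound 3 (1.21 log units; beyond the scatter) in place of (4-chlorophenyl)carbonyl, and a 2.3-fold lower number from compound 1 to compound 3 (0.36 log units; beyond the scatter) in place of benzoyl. This nitrogen therefore carries a group of more heavy atoms, with a sulfonyl link and a carboxylic acid, at a lower number than either carbonyl group shown. No supporting data bear on the reason for this. Going by these compounds, the sulfonyl link and the carboxylic acid enter together, so their shares in the step stay open. Phenylsulfonyl and 4-carboxybenzoyl on this nitrogen would separate them.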